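Furan-3-yl to Thiophen-2-yl: Expecting Compound 4

The source may report more compounds than this note shows. Statements on the series, on what has been measured and on what is new or still open speak of the compounds shown alone.

Of the compounds shown here, three on a shared core have been measured in an ADME assay on MRC5 cells (Homo sapiens), read by MTT assay, with a stated time of 72 h; a lower number here means a stronger inhibitor, a higher number a weaker inhibitor. Compound 1 `O=c1[nH]cnc2c1c(-c1ccoc1)cn2[C@@H]1O[C@H](CO)[C@@H](O)[C@H]1O` carries a furan-3-yl group, and in this assay compound 1 reaches only a limit, > 100000 nM, rather than a number. Compound 3 `CN(C)c1ncnc2c1c(-c1ccoc1)cn2[C@@H]1O[C@H](CO)[C@@H](O)[C@H]1O` differs from compound 1 elsewhere on the core; in this assay compound 3 likewise gives only a limit, > 100000 nM. Going by the values given here, compound 2 `Cc1ncnc2c1c(I)cn2[C@@H]1O[C@H](CO)[C@@H](O)[C@H]1O` differs again and is the one compound that yields a number in this assay, 13300 nM. Among the compounds with values here, compound 1 therefore stands at the limit of > 100000 nM in this assay, at which 2 of the 3 values shown sit, and since no two measured compounds differ in a single place, no measured step is at hand to guide the change ahead.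

Compound 4 `O=c1[nH]cnc2c1c(-c1cccs1)cn2[C@@H]1O[C@H](CO)[C@@H](O)[C@H]1O` has not yet been measured. It differs from compound 1 by thiophen-2-yl in place of furan-3-yl on an aromatic carbon. Both groups are five-membered aromatic rings with one hetero atom and one hydrogen-bond acceptor, so in this assay no shift beyond the usual scatter is expected, and the step of a number no higher from compound 1 to compound 4 (the limit leaves the size open) is estimated to be essentially flat, with compound 4 most likely reaching only the limit as well. Compound 4 is thus expected near 100000 nM, within a range from 30000 nM to 300000 nM.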

Compound 4, half-maximal inhibitory concentration: > 100000 nM
Compound 4 was reported as a limit; the forecaster's own chance of this, stated with the estimate: 75%; the middle value sits exactly at the limit.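

In this assay compound 4 gives > 100000 nM, a limit and not a number. Compound 1 likewise gives > 100000 nM, also a limit. Going by these compounds alone, no step between compound 1 and compound 4 can therefore be read. The compounds shown leave open whether thiophen-2-yl and furan-3-yl differ at all in this assay, and most values remain limits: the limit of > 100000 nM in this assay, at which 3 of the 4 values shown sit.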